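The source may hold more compounds than are shown below. What is called first, only, known or untested is meant among the compounds shown, and "the series" means these compounds.

Measured so far in a functional assay on SW 1116 cells (Homo sapiens) for cytotoxicity, read by MTT assay, with a stated time of 48 h; on this read-out lower numbers stand for stronger inhibition and higher numbers for weaker inhibition:
compound 1 `O=C(CSc1nnc(-c2ccncc2)o1)N/N=C/c1ccccc1` — 16700 nM
compound 2 `O=C(CSc1nnc(-c2ccncc2)o1)N/N=C/c1ccc(O)cc1` — 12200 nM
compound 3 `O=C(CSc1nnc(-c2ccncc2)o1)N/N=C/c1ccccc1F` — 21500 nM

Compound 1 sits between the other two numbers, but none of the gaps is meaningful: a 1.4-fold lower number from compound 1 to compound 2 (0.14 log units; within the scatter) and a 1.3-fold higher number from compound 1 to compound 3 (0.11 log units; within the scatter) both fall inside the scatter, as does a 1.8-fold higher number from compound 2 to compound 3 (0.25 log units; within the scatter). Across these three compounds the substitution of the phenyl on the carbon with a double bond to nitrogen has given numbers that lie within the scatter of one another.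

Compound 4 `O=C(CSc1nnc(-c2ccncc2)o1)N/N=C/c1cc(Br)ccc1O` is not yet measured. Relative to compound 1 the change is 5-bromo-2-hydroxyphenyl in place of phenyl on a carbon with a double bond to nitrogen. The measured steps that bear on it are a 1.4-fold lower number from compound 1 to compound 2 (0.14 log units; within the scatter), which brings in a hydroxy, and a 1.3-fold higher number from compound 1 to compound 3 (0.11 log units; within the scatter), which brings in a fluoro; both were within the scatter. Among the compounds with values here, compound 4 carries a hydroxy and a bromine together on the same ring; no measured step covers a bromine or this pairing, so the expectation rests on those two small steps alone. For compound 4 the expected step is a 1.1-fold lower number from compound 1 to compound 4 (0.05 log units; within the scatter), none beyond the scatter. Compound 4 is estimated at 15000 nM in this assay, with a range from 6000 nM to 40000 nM.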

Compound 4, half-maximal inhibitory concentration: 8150 nM
Beside the measured number, compound 4's estimate is 1.8-fold (0.26 log units) above it, and the stated range covers the measured number.
By their numbers in this assay, from the lowest: compounds 4, 2, 1 and 3 (each within the scatter of the next, the first and the last beyond it).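

In this assay, within the data shown here, the 5-bromo-2-hydroxyphenyl group on the carbon with a double bond to nitrogen gives the first steps at this position that lie beyond the scatter: a 2.0-fold lower number from compound 1 to compound 4 (0.31 log units; beyond the scatter) and a 2.6-fold lower number from compound 3 to compound 4 (0.42 log units; beyond the scatter) are both modest, but they show that the position can move the number when the phenyl carries this pair of groups. The comparison with the 4-hydroxyphenyl group is different, with a 1.5-fold lower number from compound 2 to compound 4 (0.18 log units; within the scatter), so compound 4 cannot be separated from compound 2 and the series shows no clear gain over a ring with a hydroxy alone. No measurement available here accounts for these steps.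

As far as these compounds go, the share of the bromine and of the hydroxy in the step from compound 1 remains open, and a 2-hydroxyphenyl without bromine and a bromophenyl without hydroxy would be needed to divide it. Also open, from the compounds shown here alone, is whether the step persists with an amine or a carboxylic acid on the same phenyl, or whether it stays confined to these halogen and hydroxy groups.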